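The source may report more compounds than this note shows. Statements on the series, on what has been measured and on what is new or still open speak of the compounds shown alone.

Compound 1, with the structure `COc1cc(C)cc(-c2c(-c3ccnc(-c4ccc(N(C)C)cc4)c3)cnn2CC#N)c1`, is one of two compounds that have been measured in a functional assay on SK-MEL-2 cells (Homo sapiens) for cytotoxicity, read by sulforhodamine B assay, with a stated time of 48 h, tested at 1 uM; on this read-out higher numbers stand for a weaker effect at the one concentration tested and lower numbers for a stronger effect. In this assay compound 1 gives 11%, the lowest of the two numbers recorded. Its nearest neighbour, compound 2, with the structure `COc1cc(C)cc(-c2nn(CC#N)cc2-c2ccnc(-c3ccc(N(C)C)cc3)c2)c1`, gives in this assay 23%, a number that lies beyond the scatter above that of compound 1. Within the data shown here, the two compounds share the same core and differ only in the way the core is joined to its substituents; no single-point step between them is set out here, so only their two values can be compared.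

The account now turns to compound 3, with the structure `COc1cc(C)cc(-c2c(-c3ccnc(-c4ccc(C(C)=O)cc4)c3)cnn2CC#N)c1`, which has not yet been measured in this assay. Compound 3 is derived from compound 1 by one change: acetyl in place of dimethylamino on an aromatic carbon. Among the measured compounds shown here, nothing measured so far shows the effect of this change, so the step is a matter of expectation. Compound 3 is expected to show a somewhat weaker effect than compound 1 in this assay, by a step of a number 14 percentage points higher from compound 1 to compound 3 (beyond the scatter), a step that may or may not exceed the scatter. Compound 3 is therefore estimated at 25%, within a range from 8% to 60%.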

Compound 3, a percentage reported as activity, at one concentration (the size of the read-out at that concentration, not a potency): 34%
For compound 3 the middle estimate is 9 percentage points below the measured one; the measured number falls inside the stated range.
By their numbers in this assay, from the lowest: compound 1; then compound 2; then compound 3.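

Among these compounds, exchanging 4-(dimethylamino)phenyl for 4-acetylphenyl gives the first direct reading at this place, on an aromatic carbon para to a large group: in this assay the read-out moves by a number 23 percentage points higher from compound 1 to compound 3 (beyond the scatter) and so the effect at the one concentration tested is weaker with acetyl. The groups that leave and enter have the same number of heavy atoms, donors and acceptors, and neither carries a ring or a net charge, so these counts do not separate them; the printed differences are an oxygen in place of a nitrogen and a double bond outside aromatic rings. Nothing measured on these compounds gives a reason for the step.

The compounds shown leave open how other groups at this place, such as a primary amine, a methoxy group or a carboxylic acid, would stand against dimethylamino and acetyl. They also leave open whether the same exchange of dimethylamino for acetyl would bring a step of similar size on compound 2 in this assay.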